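A few compounds are considered here, and "the series" means these few. Any claim that something is new, unique, unknown or untested is made for them only; others in the source may bear on it.

Measured in an assay for inhibition of Fatty-acid amide hydrolase 1 (Rattus norvegicus), using a Dixon plot; on this read-out higher numbers stand for weaker inhibition and lower numbers for stronger inhibition:
compound 1 `COC(=O)c1ccc(-c2cnc(C(=O)CCCCCCc3ccccc3)o2)nc1` gives 3.1 nM
compound 2 `O=C(CCCCCCc1ccccc1)c1ncc(-c2ccc(CO)cn2)o1` gives 3.2 nM
compound 3 `O=C(CCCCCCc1ccccc1)c1ncc(-c2ccc(CCl)cn2)o1` gives 22.4 nM

Among these three, compound 3 stands highest, which in this assay means the weakest inhibition; compounds 1 and 2 sit within the scatter of each other, as a 1.0-fold higher number from compound 1 to compound 2 (0.01 log units; within the scatter) shows. Compound 4 `N#C/C=C/c1ccc(-c2cnc(C(=O)CCCCCCc3ccccc3)o2)nc1` has not yet been measured. It differs from compound 3 in one place: 2-cyanoethenyl in place of chloromethyl on an aromatic carbon. Among the compounds with values here, two measured steps bear on this change. Replacing methoxycarbonyl by chloromethyl gave a 7.2-fold higher number from compound 1 to compound 3 (0.86 log units; beyond the scatter), and replacing hydroxy by chloro on the same chain carbon gave a 7.0-fold higher number from compound 2 to compound 3 (0.85 log units; beyond the scatter). Both say that chloromethyl at this spot goes with a clearly higher number than either alternative tried, while the two alternatives agree with each other. Within the data shown here, no measured compound carries 2-cyanoethenyl at this spot, so its own effect is unknown. Because compound 1 gave 3.1 nM and compound 2 gave 3.2 nM with other groups there, compound 4 is expected to fall back toward them, by a step of a 3.7-fold lower number from compound 3 to compound 4 (0.57 log units; beyond the scatter). Compound 4 is therefore estimated at 6 nM, with a range from 2 nM to 25 nM.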

Compound 4, inhibition constant: 2.1 nM
Compound 4: the middle estimate sits 2.9-fold (0.46 log units) above what was measured, and the stated range covers the measured number.
By their numbers in this assay, from the lowest: compounds 4, 1 and 2 (each within the scatter of the next); then compound 3.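

In this assay the swap of chloromethyl for 2-cyanoethenyl gives an 11-fold lower number from compound 3 to compound 4 (1.03 log units; beyond the scatter) and so shows that a larger group, with one double bond and one triple bond, is accepted at this position. Set against the other two groups, it shows no separation: there is a 1.5-fold lower number from compound 2 to compound 4 (0.18 log units; within the scatter) and also a 1.5-fold lower number from compound 1 to compound 4 (0.17 log units; within the scatter). Methoxycarbonyl, hydroxymethyl and 2-cyanoethenyl therefore sit at one level despite their different make-up, and among these four compounds only compound 3, with chloromethyl, stands apart.

As far as these compounds go, whether an amine, a carboxylic acid or a longer carbon chain at this spot would stay at that level remains open. Nothing shown here gives a reason why chloromethyl alone stands apart.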